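A few compounds are considered here, and "the series" means these few. Any claim that something is new, unique, unknown or untested is made for them only; others in the source may bear on it.

Compound 3 `CC(C)(C)c1ccc(C(=O)N2CCC3(CC2)C(=O)N(CC(=O)NCCCCN)CN3c2ccccc2)cc1` carries a (4-aminobutyl)amino group and gives 14500 nM in an assay on HEK293 cells for displacement of a labelled ligand from NPC1-like intracellular cholesterol transporter 1 (Homo sapiens) (on this read-out lower numbers stand for stronger inhibition and higher numbers for weaker inhibition), the highest number of the three measured and the weakest of the set. Compound 1 `CC(C)(C)c1ccc(C(=O)N2CCC3(CC2)C(=O)N(CC(=O)N2CCC(O)CC2)CN3c2ccccc2)cc1` gives 4700 nM and compound 2 `CC(C)(C)OC(=O)NCCCNC(=O)CN1CN(c2ccccc2)C2(CCN(C(=O)c3ccc(C(C)(C)C)cc3)CC2)C1=O` gives 4500 nM; the steps of a 3.1-fold higher number from compound 1 to compound 3 (0.49 log units; beyond the scatter) and a 3.2-fold higher number from compound 2 to compound 3 (0.51 log units; beyond the scatter) both lie beyond the scatter, while a 1.0-fold lower number from compound 1 to compound 2 (0.02 log units; within the scatter) is within it. Compound 4 `CC(C)(C)c1ccc(C(=O)N2CCC3(CC2)C(=O)N(CC(=O)NCCCCNS(C)(=O)=O)CN3c2ccccc2)cc1` differs from compound 3 by methylsulfonyl in place of hydrogen on an amine nitrogen. The measured step that bears most directly on this change is a 3.2-fold higher number from compound 2 to compound 3 (0.51 log units; beyond the scatter), in which a (tert-butoxycarbonyl)amino group gave way to aminomethyl and the number rose by a modest amount. Within the data shown here, the reverse direction, from an amine hydrogen to a methylsulfonyl group, is therefore expected to lower the number modestly, back towards the values of compound 1 and compound 2, though no step of this exact kind has been measured. For compound 4 a step of a 2.6-fold lower number from compound 3 to compound 4 (0.42 log units; beyond the scatter) is expected. Compound 4 is thus estimated at 5500 nM, with a range of 2500 nM to 12000 nM.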

Compound 4, half-maximal inhibitory concentration: 4500 nM
For compound 4 the middle estimate is 1.2-fold (0.09 log units) above the measured one, and the stated range covers the measured number.
By their numbers in this assay, from the lowest: compounds 2, 4 and 1 (each within the scatter of the next); then compound 3.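

In this assay, among these compounds, methylsulfonyl on the amine nitrogen gives a 3.2-fold lower number from compound 3 to compound 4 (0.51 log units; beyond the scatter) and is the first direct reading of a substituent on that nitrogen. The resulting methanesulfonamido compound cannot be told apart from the other two compounds in this assay (no change at the digits printed from compound 2 to compound 4 (within the scatter); a 1.0-fold lower number from compound 1 to compound 4 (0.02 log units; within the scatter)), so among the four compounds only compound 3, with its unsubstituted amino group, stands apart. No measured evidence bears on the reason for this step.

From the compounds shown here alone, it remains open whether the step belongs to methylsulfonyl itself or would follow from any replacement of that amine hydrogen, which a methyl or an acetyl group on the same nitrogen would test. Going by these compounds, how a carboxylic acid at the chain end, or a propyl chain ending in a free amine, would read also remains open.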